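The source may report more compounds than this note shows. Statements on the series, on what has been measured and on what is new or still open speak of the compounds shown alone.

In a toxicity assay on PC-12 cells (Rattus norvegicus) for cytotoxicity, read by MTT assay (a lower number here means a stronger inhibitor, a higher number a weaker inhibitor), compound 2 `Oc1cc(C(F)(F)F)ccc1-c1nc(-c2ccccc2O)n(-c2ccc(I)cc2)n1` gives 73300 nM, and compound 1 `Cc1ccc(-n2nc(-c3ccc(C(F)(F)F)cc3O)nc2-c2ccccc2O)cc1` gives 113000 nM, two values within the scatter of each other. Compound 3 `Cc1cc(C)cc(-n2nc(-c3ccc(C(F)(F)F)cc3O)nc2-c2ccccc2O)c1` carries 3,5-dimethylphenyl in place of 4-iodophenyl on an aromatic nitrogen. Going by the values given here, the only measured step, a 1.5-fold lower number from compound 1 to compound 2 (0.19 log units; within the scatter), exchanges iodo for methyl on an aromatic carbon and stays within the scatter. No change beyond the scatter is therefore expected in this assay, and no direction is favoured. The expected value for compound 3 is 90000 nM, with an estimated range from 40000 nM to 200000 nM. The expected step is a 1.2-fold higher number from compound 2 to compound 3 (0.09 log units; within the scatter).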

Compound 3, half-maximal inhibitory concentration: 263000 nM
The estimate for compound 3 lay 2.9-fold (0.47 log units) below the measured number, outside the stated range (above it).
By their numbers in this assay, from the lowest: compounds 2 and 1 (each within the scatter of the next); then compound 3.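

At this position on the aromatic nitrogen, swapping the aryl group can move the number in this assay beyond the scatter, which the exchange of 4-methylphenyl and 4-iodophenyl did not show. 3,5-Dimethylphenyl raises the number by a modest step from both neighbours (a 3.6-fold higher number from compound 2 to compound 3 (0.55 log units; beyond the scatter); a 2.3-fold higher number from compound 1 to compound 3 (0.37 log units; beyond the scatter)). No measurement available here accounts for this rise.

The compounds shown do not separate the effect of the second methyl from that of where the methyls sit. As far as these compounds go, how a plain phenyl, an amine or a carboxylic acid at this aryl group would read also remains open.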